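Replacing the aryl group on the ring nitrogen of compound 2

The source may report more compounds than this note shows. Statements on the series, on what has been measured and on what is new or still open speak of the compounds shown alone.

Of the compounds shown here, three sharing one core have been measured in a functional assay on SK-N-SH cells (Homo sapiens) for inhibition, read by sulforhodamine B assay, with a stated time of 48 h; on this read-out lower numbers stand for stronger inhibition and higher numbers for weaker inhibition. Compound 1 `CO[C@@H]1CC=C2NN(c3cc4ccccc4[nH]3)C(=O)C[C@]2(c2ccncc2)O1` gives 3900 nM in this assay. Compound 3 `CO[C@@H]1CC=C2NN(c3ccc(C)cc3)C(=O)C[C@]2(c2ccccc2)O1` gives 11100 nM. Compound 2 `CO[C@@H]1CC=C2NN(c3ccc(Cl)cc3)C(=O)C[C@]2(C)O1` gives 31700 nM, the highest of the three numbers: its gap to compound 3 and its gap to compound 1 both lie beyond the usual scatter of this assay. No two of these compounds differ in one place only, so no single change can be tied to any of these gaps.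

The step now followed leads from compound 2 to compound 4 `CO[C@@H]1CC=C2NN(c3cccnc3)C(=O)C[C@]2(C)O1`, which has not yet been measured in this assay. The change is pyridin-3-yl in place of 4-chlorophenyl on an amide-type nitrogen in a ring. The group that enters is smaller than the one that leaves and carries one hydrogen-bond acceptor where the leaving group carries none.

Among the measured compounds shown here, no measured pair shows the effect of this change on the shared core. In this assay compound 4 is therefore expected to stay close to compound 2, with a step of a 1.1-fold higher number from compound 2 to compound 4 (0.04 log units; within the scatter) that is expected to remain within the scatter, and a wide range is kept around the estimate. The number for compound 4 is estimated at 35000 nM, between 12000 nM and 100000 nM.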

Compound 4, half-maximal inhibitory concentration: 19000 nM
For compound 4 the middle estimate is 1.8-fold (0.27 log units) above the measured one, and the stated range covers the measured number.
By their numbers in this assay, from the lowest: compound 1; then compounds 3, 4 and 2 (each within the scatter of the next, the first and the last beyond it).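

In this assay, among the compounds shown here, compound 2 and compound 4 form the first pair that differs in one place only, and this pair gives a step (a 1.7-fold lower number from compound 2 to compound 4 (0.22 log units; within the scatter)) that can be tied to a single change. On the amide-type nitrogen in a ring of the shared core, with the methyl group kept, pyridin-3-yl and 4-chlorophenyl therefore cannot be told apart: a ring with one hetero atom and one hydrogen-bond acceptor takes the place of a carbon-only ring bearing chlorine without a step beyond the scatter, although this rests on one pair alone. No measurement is at hand that would explain this reading.

For the compounds shown here, whether an aminoalkyl group, a carboxylic acid or a plain alkyl chain on this nitrogen would give a step beyond the scatter remains open, as the only groups compared here in one step are two six-membered aromatic rings. On these data alone, it also remains open whether the same exchange would read alike on a core that carries phenyl in place of the methyl group.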